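A few compounds are considered here, and "the series" means these few. Any claim that something is new, unique, unknown or untested is made for them only; others in the source may bear on it.

In a functional assay on MCF7 cells (Homo sapiens) for inhibition, read by MTT assay, with a stated time of 72 h (on this read-out higher numbers stand for weaker inhibition and lower numbers for stronger inhibition), three compounds sharing one core have been measured. Compound 1 `C=C(Br)C(=O)Nc1cccc(/C=C/C(=O)Nc2ccc(F)cc2)c1`, with 4-fluorophenyl on the amide-type nitrogen, gives 13600 nM. Compound 2 `C=C(Br)C(=O)Nc1cccc(/C=C/C(=O)Nc2ccc(F)c(F)c2)c1`, with 3,4-difluorophenyl there, gives 2690 nM. Compound 3 `C=C(Br)C(=O)Nc1cccc(/C=C/C(=O)NCc2ccc(C)cc2)c1`, with 4-methylbenzyl there, gives 2200 nM.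

Compound 3 stands at the low end of the three numbers. That end is shared, with a 1.2-fold lower number from compound 2 to compound 3 (0.09 log units; within the scatter), while the high end lies further off, with a 6.2-fold lower number from compound 1 to compound 3 (0.79 log units; beyond the scatter).

Compound 4 `C=C(Br)C(=O)Nc1cccc(/C=C/C(=O)Nc2ccc(OC)cc2)c1` carries 4-methoxyphenyl in place of 4-methylbenzyl on the amide-type nitrogen (4-methoxyphenyl in place of 4-methylbenzyl on an amide-type nitrogen). Its group most resembles the 4-fluorophenyl of compound 1, so the closest guide is a 6.2-fold lower number from compound 1 to compound 3 (0.79 log units; beyond the scatter), read in reverse. Among the compounds with values here, that reversal need not be complete, since one added fluoro already gave a 5.1-fold lower number from compound 1 to compound 2 (0.70 log units; beyond the scatter), and no measured compound carries a methoxy group. A modest move to a higher number is therefore expected, estimated as a 2.7-fold higher number from compound 3 to compound 4 (0.44 log units; beyond the scatter). The expected value for compound 4 is 6000 nM, with an estimated range from 1800 nM to 20000 nM.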

Compound 4, half-maximal inhibitory concentration: 2500 nM
Compound 4: middle estimate off by 2.4-fold (0.38 log units), on the high side; the measured number falls inside the stated range.
By their numbers in this assay, from the lowest: compounds 3, 4 and 2 (each within the scatter of the next); then compound 1.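

Replacing fluoro with methoxy on the aromatic ring gives a 5.4-fold lower number from compound 1 to compound 4 (0.74 log units; beyond the scatter) in this assay, so a change to a single group on this ring can move compound 1 beyond the scatter, without a second fluoro or a 4-methylbenzyl group. With a 1.1-fold higher number from compound 3 to compound 4 (0.06 log units; within the scatter) and a 1.1-fold lower number from compound 2 to compound 4 (0.03 log units; within the scatter), the 4-methoxyphenyl, 4-methylbenzyl and 3,4-difluorophenyl groups cannot be told apart on this amide-type nitrogen, and among these four compounds only compound 1, with 4-fluorophenyl, stands apart. Nothing available here accounts for the gap between the methoxy and fluoro compounds.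

As far as these compounds go, it remains open whether a phenyl ring carrying an amine or a carboxylic acid would depart from the values shared by compound 2, compound 3 and compound 4. Also open, from the compounds shown here alone, is whether a plain phenyl group would fall with compound 1 or with those three.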